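The source may hold more compounds than are shown below. What is called first, only, known or untested is meant among the compounds shown, and "the series" means these compounds.

All three measured compounds were tested in a functional assay on HCT-116 cells (Homo sapiens) for inhibition, read by MTT assay, with a stated time of 48 h; on this read-out lower numbers stand for stronger inhibition and higher numbers for weaker inhibition:

- compound 1, `COc1ccc(CN(C(C)=O)c2cc(OC)c(OC)c(OC)c2)cc1O`, gives 270 nM
- compound 2, `COc1cc(NCc2ccc(Br)cc2)cc(OC)c1OC`, gives > 80000 nM
- compound 3, `COc1ccc(CN(C(=O)CCl)c2cc(OC)c(OC)c(OC)c2)cc1O`, gives 250 nM

The value of compound 2 is a limit of this assay rather than a number, as shown by the limit of > 80000 nM in this assay, at which 1 of the 3 values shown sits. Among the two numbers, compound 1 stands highest, and its nearest neighbour is compound 3: the step of a 1.1-fold lower number from compound 1 to compound 3 (0.03 log units; within the scatter) is within the scatter, so the two cannot be told apart.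

The compound still to be measured is compound 4, `C/C=C/C(=O)N(Cc1ccc(OC)c(O)c1)c1cc(OC)c(OC)c(OC)c1`. It differs from compound 1 only at the carbonyl carbon of the amide: prop-1-en-1-yl in place of methyl on a carbonyl carbon. Within the data shown here, the one measured step, from compound 1 to compound 3, changes a saturated chain carbon bound to the carbonyl carbon and leaves the number essentially unchanged. Among the measured compounds shown here, no measured step touches the carbonyl carbon itself, so the measured steps give only weak guidance for this change. On that basis, compound 4 is expected to stay close to compound 1, with a step of a 1.1-fold lower number from compound 1 to compound 4 (0.03 log units; within the scatter) that is expected to lie within the scatter. The estimate for compound 4 in this assay is 250 nM, expected to fall between 80 nM and 800 nM.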

Compound 4, half-maximal inhibitory concentration: 55 nM
Beside the measured number, compound 4's estimate is 4.5-fold (0.66 log units) above it, outside the stated range (below it).
By their numbers in this assay, from the lowest: compound 4; then compounds 3 and 1 (each within the scatter of the next). At a limit, above all of these: compound 2.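

Among these compounds, putting prop-1-en-1-yl in place of methyl on the carbonyl carbon gives a 4.9-fold lower number from compound 1 to compound 4 (0.69 log units; beyond the scatter) in this assay, the first step at this position that lies beyond the scatter. Set against chloromethyl, the same group gives a 4.5-fold lower number from compound 3 to compound 4 (0.66 log units; beyond the scatter), so the lower number appears from both of the groups measured earlier. The position therefore does respond to what sits on the carbonyl carbon, something the earlier pair could not show, since the values of compound 1 and compound 3 lie within the scatter of each other.

This change adds carbon atoms and a double bond outside aromatic rings at once, so the compounds shown leave open which of the two goes with the lower number, and a saturated propyl chain on the same carbonyl carbon would separate them, while a longer chain or a terminal amine would show how far the trend extends. Nothing shown gives a reason for the lower number of compound 4.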